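The compounds below may be only part of what the source reports. "The series", "measured", "known", "first", "only" and "open" are said of these compounds alone.

Compound 1 `COc1ccc(Nc2nc(-c3cccc(F)c3)nc3ccc(F)cc23)cc1` is the only one of the three measured compounds that gives a number in a functional assay on COLO 205 cells (Homo sapiens) for cytotoxicity, read by MTT assay, with a stated time of 48 h; on this read-out lower numbers stand for stronger inhibition and higher numbers for weaker inhibition: compound 1 gives 46800 nM. Compound 2 `Fc1cccc(Nc2nc(-c3cccc(F)c3)nc3ccc(F)cc23)c1` carries 3-fluorophenyl in place of 4-methoxyphenyl on a nitrogen on an aromatic ring; in this assay compound 2 reaches only a limit of the assay, > 50000 nM. Compound 3 `Oc1cccc(Nc2nc(-c3cccc(F)c3)nc3ccc(F)cc23)c1` carries 3-hydroxyphenyl in place of 4-methoxyphenyl on a nitrogen on an aromatic ring; in this assay compound 3 likewise gives only a limit, > 50000 nM. Hence an at least 1.0-fold higher number from compound 1 to compound 2 (0.02 log units; that floor lies within the scatter) and an at least 1.0-fold higher number from compound 1 to compound 3 (0.02 log units; that floor lies within the scatter), while a step that the two limits leave unreadable from compound 2 to compound 3. Two of the three values thus sit at the limit of > 50000 nM in this assay, at which 2 of the 3 values shown sit.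

Compound 4 `Oc1ccccc1Nc1nc(-c2cccc(F)c2)nc2ccc(F)cc12` is not yet measured. It differs from compound 1 in one place: 2-hydroxyphenyl in place of 4-methoxyphenyl on a nitrogen on an aromatic ring. Going by the values given here, the nearest measured step is the one to compound 3, where 3-hydroxyphenyl in place of 4-methoxyphenyl took the number at least up to the limit, an at least 1.0-fold higher number from compound 1 to compound 3 (0.02 log units; that floor lies within the scatter); compound 2 shows the same, an at least 1.0-fold higher number from compound 1 to compound 2 (0.02 log units; that floor lies within the scatter). Since the number for compound 1 is already high, a step of that kind, or none beyond the scatter, is expected in this assay, with the result more likely at the limit than below it. The expected step is a 1.2-fold higher number from compound 1 to compound 4 (0.07 log units; within the scatter). Compound 4 is therefore estimated at 55000 nM, in the range 25000 nM to 150000 nM.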

Compound 4, half-maximal inhibitory concentration: > 50000 nM
Compound 4: no number, only a limit (the forecaster's own chance of this, stated with the estimate: 60%); the middle value does not contradict the limit.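

In this assay compound 4, with 2-hydroxyphenyl on the nitrogen, gives only a limit, > 50000 nM. Going by these compounds alone, the one readable step is an at least 1.0-fold higher number from compound 1 to compound 4 (0.02 log units; that floor lies within the scatter), so this change can be stated only as a floor, and the steps among compound 2, compound 3 and compound 4 cannot be read. What compound 4 adds is a third group in place of 4-methoxyphenyl that gives no number, and the 2-hydroxyphenyl group ends in the same place as the 3-hydroxyphenyl group of compound 3, so compound 1 remains the only compound with a number and the values now gather at one point: the limit of > 50000 nM in this assay, at which 3 of the 4 values shown sit.

The compounds shown leave open how far apart compound 2, compound 3 and compound 4 really lie, and whether any group at this position can bring the number clearly under the limit. They also do not tell how an amine or a carboxylic acid on this phenyl ring would read in this assay, or a longer chain such as ethoxy in place of the methoxy of compound 1.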